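Swapping the aryl group of compound 3

The source may report more compounds than this note shows. Statements on the series, on what has been measured and on what is new or still open speak of the compounds shown alone.

In a functional assay, with a stated time of 19 h (a lower number here means a stronger inhibitor, a higher number a weaker inhibitor), compound 1 `COc1ccc(/C=C/C(O)=C/C(=O)/C=C/c2ccc(O)c(CN(C)C)c2)cc1` gives 11900 nM, compound 2 `CN(C)Cc1cc(/C=C/C(=O)/C=C(O)/C=C/c2ccc(F)cc2)ccc1O` gives 22300 nM, and compound 3 `COc1ccc(/C=C/C(O)=C/C(=O)/C=C/c2ccc(O)c(CN(C)C)c2)cc1OC` gives 27400 nM. Two measured steps place this last value: a 2.3-fold higher number from compound 1 to compound 3 (0.36 log units; beyond the scatter) and a 1.2-fold higher number from compound 2 to compound 3 (0.09 log units; within the scatter). A third step, a 1.9-fold higher number from compound 1 to compound 2 (0.27 log units; within the scatter), completes the set. Compound 4 `CN(C)Cc1cc(/C=C/C(=O)/C=C(O)/C=C/c2ccc(O)cc2)ccc1O` brings (4-hydroxyphenyl in place of 3,4-dimethoxyphenyl on a double-bonded chain carbon bound to a double-bonded chain carbon). Among the measured compounds shown here, none of the measured compounds carries 4-hydroxyphenyl at this place, so the evidence is indirect. The largest measured step, a 2.3-fold higher number from compound 1 to compound 3 (0.36 log units; beyond the scatter), is only modest, and it runs towards the 3,4-dimethoxyphenyl group that leaves here. A small move in the opposite direction is therefore expected in this assay, namely a 1.7-fold lower number from compound 3 to compound 4 (0.23 log units; within the scatter), which would stay within the scatter. Compound 4 is estimated at 16000 nM, with an expected range of 6500 nM to 36000 nM.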

Compound 4, half-maximal inhibitory concentration: 7600 nM
Estimate against measurement, compound 4: 2.1-fold (0.32 log units) above; the measured number falls inside the stated range.
By their numbers in this assay, from the lowest: compounds 4, 1, 2 and 3 (each within the scatter of the next, the first and the last beyond it).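

In this assay a hydroxy group at this place reads better than two of the other groups, with the change to 4-hydroxyphenyl giving (a 3.6-fold lower number from compound 3 to compound 4 (0.56 log units; beyond the scatter)) and hydroxy in place of fluoro giving (a 2.9-fold lower number from compound 2 to compound 4 (0.47 log units; beyond the scatter)). Among the compounds shown here, removing the methyl from the single methoxy group gives only (a 1.6-fold lower number from compound 1 to compound 4 (0.19 log units; within the scatter)), so hydroxy and methoxy are not separated here. Nothing given here explains these differences.

The compounds shown leave open how an amine or a carboxylic acid would read on this aromatic ring. They also leave open whether 4-hydroxyphenyl keeps its reading alongside a second hydroxy group.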